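Series notes: glutamate-to-alanine step on the shared core

The source may hold more compounds than are shown below. What is called first, only, known or untested is meant among the compounds shown, and "the series" means these compounds.

In a functional assay on the whole organism (Tail, strain ICR) with Mus musculus as the target, in the tail flick test, with a stated time of 60 min, at a dose of 25 umol/kg by the oral route (a higher number here means a stronger effect of the compound at the dose given, a lower number a weaker effect), compound 1 `O=C(O)CC[C@H](NC(=O)CN(c1nc(Cl)nc2[nH]cnc12)C1CC1)C(=O)O` gives 33.3%. Compound 2 `CC[C@H](C)[C@H](NC(=O)CN(c1nc(Cl)nc2[nH]cnc12)C1CC1)C(=O)OCc1ccccc1` gives 40.6% in this assay, a number within the scatter of compound 1. Compound 3 `C[C@H](NC(=O)CN(c1ncnc2c1ncn2C1CCCCO1)C1CC1)C(=O)OCc1ccccc1` gives 53% in this assay, which lies beyond the scatter above compound 1. Compound 4 `C[C@H](NC(=O)CN(c1nc(Cl)nc2[nH]cnc12)C1CC1)C(=O)O` has not been measured. It differs from compound 1 by hydrogen in place of carboxymethyl on a saturated chain carbon, two bonds along the chain from an amide-type nitrogen and a carbonyl carbon. Among the compounds with values here, no measured pair shows this change alone, so no step size is known for it. The nearest hint is compound 3, whose 53% is reached with a 1-carboxyethyl chain, though on a different core and as a benzyl ester. The expected step from compound 1 to compound 4 in this assay is a number 6.7 percentage points higher from compound 1 to compound 4 (within the scatter), a small rise that may stay within the scatter. Compound 4 is expected to give 40% in this assay, with a range from 22% to 58%.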

Compound 4, a percentage reported as activity, at one dose (the size of the read-out at that dose, not a potency): 44.6%
Beside the measured number, compound 4's estimate is 4.6 percentage points below it; the measured number falls inside the stated range.
By their numbers in this assay, from the lowest: compounds 1, 2, 4 and 3 (each within the scatter of the next, the first and the last beyond it).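

In this assay, within the data shown here, hydrogen in place of carboxymethyl at this position gives a number 11.3 percentage points higher from compound 1 to compound 4 (beyond the scatter), the first step read on the shared core with only this change. At this dose, then, the carboxymethyl group is not required for the effect, and removing it raises the read-out. Nothing at hand accounts for the step. From the compounds shown here alone, whether an amine or a hydroxyl group at this position would give a similar read-out remains open. So does whether the step keeps its size when the free carboxylic acid becomes a benzyl ester.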